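Aminocyclohexyl in place of aminophenyl on the ring nitrogen

This account rests on a few compounds, and the source may have more. Where it says the series, first, only, none or still open, it means among the compounds named here.

The series is followed in a functional assay on HCT-116 cells (Homo sapiens) for cytotoxicity, read by MTT assay, with a stated time of 72 h; on this read-out lower numbers stand for stronger inhibition and higher numbers for weaker inhibition. Compound 1 `Nc1ccc(Nc2c(C(=O)NCc3ccc(F)cc3)nc(Br)c3cccnc23)cc1` gives 10000 nM in this assay. Compound 2 `CS(=O)(=O)NCCCN(c1nc(C(=O)NCc2ccc(F)cc2)c(O)c2ncccc12)S(C)(=O)=O` gives 15000 nM, and compound 3 `N[C@H]1CC[C@H](NC(=O)c2nc(Br)c3cccnc3c2NCc2ccc(F)cc2)CC1` gives 6400 nM. Compound 1 stands second highest of the three numbers; its nearest neighbour is compound 2, its furthest is compound 3, and both gaps lie within the scatter, so the three compounds show no separation in this assay.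

Compound 4 `N[C@H]1CC[C@H](Nc2c(C(=O)NCc3ccc(F)cc3)nc(Br)c3cccnc23)CC1` is not yet measured. It differs from compound 1 at one place: 4-aminocyclohexyl in place of 4-aminophenyl on a nitrogen on an aromatic ring. Cut one bond further out, the same difference reads (4-aminophenyl)amino to (4-aminocyclohexyl)amino, on a nitrogen on an aromatic ring whose other neighbours are aromatic carbon.

Going by the values given here, no measured pair in the set differs in exactly this way, so the size of the step has no direct precedent here. Compound 3 carries a 4-aminocyclohexyl group on a different nitrogen and gives 6400 nM, a number within the scatter of compound 1. For compound 4 the expected step is a 1.3-fold lower number from compound 1 to compound 4 (0.12 log units; within the scatter), a movement that is expected to stay within the scatter, in no firm direction. Compound 4 is accordingly estimated at 7500 nM, with a range of 2500 nM to 22000 nM.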

Compound 4, half-maximal inhibitory concentration: 7000 nM
For compound 4 the middle estimate is 1.1-fold (0.03 log units) above the measured one; the measured number falls inside the stated range.
By their numbers in this assay, from the lowest: compounds 3, 4, 1 and 2 (each within the scatter of the next, the first and the last beyond it).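

In this assay, going by these compounds alone, a 1.4-fold lower number from compound 1 to compound 4 (0.15 log units; within the scatter) gives the first direct reading at this position, and the replacement of 4-aminophenyl by 4-aminocyclohexyl on a nitrogen on an aromatic ring stays within the scatter. In this one pair, therefore, exchanging a six-membered aromatic ring of carbon only for a non-aromatic one, with 2 defined stereocentres entering, produces no separable change in the read-out, although it remains a single comparison on a single core. No supporting measurement accompanies this result, so the absence of a separable change remains unexplained.

On these data alone, it remains open whether this tolerance extends to other groups at the same nitrogen, such as a 4-carboxycyclohexyl group, a piperidin-4-yl group or an open 4-aminobutyl chain, any of which might move the number beyond the scatter. The compounds shown also leave open how the other stereoisomer of the 4-aminocyclohexyl group would read, since only one defined arrangement appears at this position.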